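Propyl ester to benzyl ester on a shared core

The source may report more compounds than this note shows. Statements on the series, on what has been measured and on what is new or still open speak of the compounds shown alone.

Compound 1 `CCCOC(=O)C1=C(C)NC(=O)NC1c1ccoc1` and compound 2 `CCCOC(=O)C1=C(C)NC(=O)NC1c1cccs1` share one core and differ only in the aromatic ring on the saturated ring carbon. In an assay on membranes from HeLa cells for displacement of a labelled ligand from adenosine receptor A3 (Homo sapiens), read by scintillation counting, with a stated time of 180 min, tested at 1 uM (a lower number here means less inhibition, a higher number more inhibition at the concentration tested (going by the name of the read-out)), compound 1 gives 11% and compound 2 gives 32%; the step of a number 21 percentage points higher from compound 1 to compound 2 (beyond the scatter) leaves compound 2 the higher of the two numbers. Compound 3 `CC1=C(C(=O)OCc2ccccc2)C(c2cccs2)NC(=O)N1` keeps the thiophen-2-yl of compound 2 and alters the ester instead: phenyl in place of ethyl on a saturated chain carbon bound to an oxygen next to a carbonyl group. Among the compounds with values here, no measured step touches this part of the molecule, so nothing measured bears on it directly, and only a small change is expected. Compound 3 is therefore estimated at 36%, between 15% and 60%. The expected step in this assay is a number 4 percentage points higher from compound 2 to compound 3 (within the scatter).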

Compound 3, a percentage reported as inhibition, at one concentration (the size of the read-out at that concentration, not a potency): 8%
The estimate for compound 3 lay 28 percentage points above the measured number; measured number outside the range, below it.
By their numbers in this assay, from the lowest: compounds 3 and 1 (each within the scatter of the next); then compound 2.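

Within the data shown here, the ester chain, which no earlier step had touched, proves able to change the result: in this assay, propyl to benzyl gives a number 24 percentage points lower from compound 2 to compound 3 (beyond the scatter), while the thiophen-2-yl stays in place. This position therefore cannot be treated as a silent part of the molecule, at least on this core. Nothing available explains why inhibition falls with this change. The compounds shown leave open how a methyl ester, a butyl ester or a carboxylic acid would read here. They also leave open whether benzyl would have a similar effect alongside furan-3-yl.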